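Phenylpropyl ether replaces methoxyethyl ether on the shared core

The source may hold more compounds than are shown below. What is called first, only, known or untested is meant among the compounds shown, and "the series" means these compounds.

Going by the values given here, compound 2 `CCCCNc1nc(N)nnc1OCCOC` gives the highest number so far in an assay on isolated protein for agonist activity at Toll-like receptor 8 (Homo sapiens) (a lower number here means that less compound is needed, a higher number that more compound is needed for the effect), at 1000 nM. Among the compounds with values here, its nearest neighbour, compound 1 `CCCCNc1nc(N)nnc1OCCCN(C)C`, gives 100 nM, and the step of a 10-fold higher number from compound 1 to compound 2 (1.00 log units; beyond the scatter) is the only measured step on the shared core. Compound 3 `CCCCNc1nc(N)nnc1OCCCc1ccccc1` is not yet measured; relative to compound 2 the change is benzyl in place of methoxy on a saturated chain carbon, two bonds along the chain from an oxygen on an aromatic ring. That earlier step shows the same chain position is sensitive to what it carries, since swapping (dimethylamino)methyl for methoxy moved the number well beyond the scatter. Within the data shown here, nothing measured carries a benzyl or any ring at that position, so the direction of the new step rests on no direct precedent. The author expects compound 3 to give 400 nM in this assay, within 100 nM to 2000 nM. The expected step, a 2.5-fold lower number from compound 2 to compound 3 (0.40 log units; beyond the scatter), is therefore a moderate move with wide uncertainty.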

Compound 3, half-maximal effective concentration: 1930 nM
Estimate against measurement, compound 3: 4.8-fold (0.68 log units) below, and the stated range covers the measured number.
By their numbers in this assay, from the lowest: compound 1; then compounds 2 and 3 (each within the scatter of the next).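

In this assay, replacing methoxy with benzyl on this saturated chain carbon gives a 1.9-fold higher number from compound 2 to compound 3 (0.29 log units; within the scatter), so a large all-carbon aromatic group and a small ether group cannot be told apart at this position. Replacing dimethylamino with phenyl, three bonds along the chain from an oxygen on an aromatic ring, gives a 19-fold higher number from compound 1 to compound 3 (1.29 log units; beyond the scatter), and so among these three compounds only compound 1, the one carrying dimethylamino, stands apart from the other two, with both of its steps beyond the scatter. The data offer no explanation for these numbers.

The compounds shown leave open whether the gain goes with dimethylamino alone or would also appear with a primary amine, a pyrrolidine or a morpholine at the chain end. They also leave open how a shorter or longer chain ending in dimethylamino, or a carboxylic acid at that end, would read.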